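A few compounds are considered here, and "the series" means these few. Any claim that something is new, unique, unknown or untested is made for them only; others in the source may bear on it.

Compound 2 `Cn1ncc(Cl)c1-c1cc(C(=O)N[C@@H]2CN[C@H](CCCO)C[C@H]2c2ccc(Cl)c(Cl)c2)oc1Cl` carries a 3-hydroxypropyl chain on the saturated ring. Among the compounds with values here, in a functional assay on HCT-116 cells (Homo sapiens) for antiproliferative activity, read by sulforhodamine B assay, with a stated time of 72 h (a lower number here means a stronger inhibitor, a higher number a weaker inhibitor), compound 2 gives 510 nM, the lower of the two numbers measured so far; compound 1 `Cn1ncc(Cl)c1-c1cc(C(=O)N[C@@H]2CN[C@H](CCNS(C)(=O)=O)C[C@H]2c2ccc(F)c(F)c2)oc1Cl` gives 920 nM in this assay, and the two values lie within the scatter of each other. Compound 3 `Cn1ncc(Cl)c1-c1cc(C(=O)N[C@@H]2CN[C@H](CC(=O)NC3CC3)C[C@H]2c2ccc(Cl)c(Cl)c2)oc1Cl` has not been measured. It differs from compound 2 by cyclopropylcarbamoyl in place of 2-hydroxyethyl on a saturated chain carbon bound to a saturated ring carbon. Within the data shown here, no measured pair shows this exchange, so the step from compound 2 to compound 3 is expected to stay within the scatter, with no direction favoured, estimated as a 1.1-fold higher number from compound 2 to compound 3 (0.03 log units; within the scatter). Compound 3 is therefore expected to give about 550 nM in this assay, with a range from 200 nM to 1600 nM.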

Compound 3, half-maximal inhibitory concentration: 740 nM
Compound 3: middle estimate off by 1.3-fold (0.13 log units), on the low side; low and high end bracket the measured number.
By their numbers in this assay, from the lowest: compounds 2, 3 and 1 (each within the scatter of the next).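

In this assay, cyclopropylcarbamoyl in place of 2-hydroxyethyl on a saturated chain carbon bound to a saturated ring carbon gives a 1.5-fold higher number from compound 2 to compound 3 (0.16 log units; within the scatter), so this position takes both groups without a step beyond the scatter. The entering group is larger and brings a three-membered ring, yet the numbers stay within the scatter. Nothing available explains this result. Going by these compounds, whether an amine or a carboxylic acid on this chain, or a longer chain, would move the number beyond the scatter remains open.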